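The source may report more compounds than this note shows. Statements on the series, on what has been measured and on what is new or still open speak of the compounds shown alone.

Working notes on the series in a functional assay on isolated protein for inhibition of Glucose-dependent insulinotropic receptor (Rattus norvegicus), read by HTRF and cAMP accumulation; on this read-out lower numbers stand for an effect already at smaller amounts and higher numbers for an effect only at larger amounts of compound. Among the measured compounds shown here, compound 3 `Cc1nc(S(C)(=O)=O)ccc1Oc1ncnc(OC2CCN(C(=O)C(F)(F)F)CC2)c1F` gives 880 nM, the second highest of the three numbers so far. Compound 2 `Cc1nc(S(C)(=O)=O)ccc1Oc1ncnc(OC2CCN(C(=S)OC(C)C)CC2)c1F` gives 1050 nM, with a 1.2-fold lower number from compound 2 to compound 3 (0.08 log units; within the scatter). Compound 1 `Cc1nc(S(C)(=O)=O)ccc1Oc1ncnc(OC2CCN(C(=O)SC(C)(C)C)CC2)c1F` gives 30.7 nM; the step of a 29-fold higher number from compound 1 to compound 3 (1.46 log units; beyond the scatter) is the one large move on this carbonyl carbon, and a 34-fold higher number from compound 1 to compound 2 (1.53 log units; beyond the scatter) is similar in size. Compound 4 `Cc1nc(S(C)(=O)=O)ccc1Oc1ncnc(OC2CCN(C(=O)C(C)(C)F)CC2)c1F` is the next member: 1-fluoro-1-methylethyl in place of trifluoromethyl on a carbonyl carbon. For the measured compounds named here, only the step from compound 1 to compound 3 bears on this position directly, and it shows that a branched, sulfur-bearing group outperforms trifluoromethyl. A branched carbon group with one fluorine is expected to recover part of that, so compound 4 is estimated at 180 nM (range 45 nM to 700 nM), a step of a 4.9-fold lower number from compound 3 to compound 4 (0.69 log units; beyond the scatter) expected toward lower numbers.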

Compound 4, half-maximal effective concentration: 296 nM
Compound 4: middle estimate off by 1.6-fold (0.22 log units), on the low side, within the range that was stated.
By their numbers in this assay, from the lowest: compound 1; then compound 4; then compounds 3 and 2 (each within the scatter of the next).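

In this assay, among the compounds shown here, the single change on this carbonyl carbon gives a 3.0-fold lower number from compound 3 to compound 4 (0.47 log units; beyond the scatter) and so shows that a group without sulfur can still lower the number here, with a 3.5-fold lower number from compound 2 to compound 4 (0.55 log units; beyond the scatter) pointing the same way. The (tert-butyl)sulfanyl group of compound 1 nevertheless keeps the lowest number of the four, since a 9.6-fold higher number from compound 1 to compound 4 (0.98 log units; beyond the scatter) remains to be made up. Nothing measured here accounts for these steps. Going by these compounds, whether tert-butyl without fluorine, or tert-butoxy, on the same carbonyl carbon would close that remaining gap stays open.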